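The source may hold more compounds than are shown below. What is called first, only, known or untested is meant among the compounds shown, and "the series" means these compounds.

Compound 1 `COC(C)CO[C@H](CC=C(C)C)C1=CC(=O)c2c(O)ccc(O)c2C1=O` gives 16600 nM in a functional assay on DU-145 cells (Homo sapiens) for cytotoxicity, read by MTT assay; on this read-out higher numbers stand for weaker inhibition and lower numbers for stronger inhibition. Compound 2 `CCCCCCC(C)(O)CC(=O)O[C@H](CC=C(C)C)C1=CC(=O)c2c(O)ccc(O)c2C1=O` reaches only a limit of the assay, > 100000 nM. Compound 3 `CC(C)=CC[C@@H](OC(=O)CC(C)(O)C(C)C)C1=CC(=O)c2c(O)ccc(O)c2C1=O` gives 16900 nM.

Compound 3 holds the highest of the two numbers shown, though its nearest neighbour, compound 1, sits within the scatter: a 1.0-fold higher number from compound 1 to compound 3 (0.01 log units; within the scatter). Compound 4 `CCCCC(C)(O)CC(=O)O[C@H](CC=C(C)C)C1=CC(=O)c2c(O)ccc(O)c2C1=O` differs from compound 3 by butyl in place of isopropyl on a saturated chain carbon bound to an oxygen on a saturated carbon and two saturated chain carbons. The step that bears on this is an at least 5.9-fold lower number from compound 2 to compound 3 (0.77 log units; beyond the scatter), which is set by compound 2 standing at the limit of > 100000 nM in this assay, at which 1 of the 3 values shown sits. Going back toward a longer chain is therefore expected to raise the number, though less than the full way to the limit, an expected step of a 2.4-fold higher number from compound 3 to compound 4 (0.37 log units; beyond the scatter). Compound 4 is estimated at 40000 nM, between 15000 nM and 120000 nM.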

Compound 4, half-maximal inhibitory concentration: 76500 nM
For compound 4 the middle estimate is 1.9-fold (0.28 log units) below the measured one; the range from low to high includes it.
By their numbers in this assay, from the lowest: compounds 1 and 3 (each within the scatter of the next); then compound 4. At a limit, above all of these: compound 2.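

Within the data shown here, on the saturated chain carbon, the earlier compounds showed a loss only at the limit held by compound 2, whereas butyl in place of isopropyl gives a measured step, a 4.5-fold higher number from compound 3 to compound 4 (0.66 log units; beyond the scatter). The same rise appears against the ether side chain of compound 1, with a 4.6-fold higher number from compound 1 to compound 4 (0.66 log units; beyond the scatter). Against compound 2 the step is only a floor, an at least 1.3-fold lower number from compound 2 to compound 4 (0.11 log units; that floor lies within the scatter), so compound 4 is not separated from it: the limit of > 100000 nM in this assay, at which 1 of the 4 values shown sits.

The compounds shown leave open whether the rise follows chain length or the loss of branching. A straight propyl chain or a tert-butyl group at this place would help to separate the two.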